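Chloro in place of hydrogen on the phenyl of compound 2

This account rests on a few compounds, and the source may have more. Where it says the series, first, only, none or still open, it means among the compounds named here.

In a functional assay on A549 cells (Homo sapiens) for cytotoxicity, read by MTT assay, with a stated time of 48 h (on this read-out lower numbers stand for stronger inhibition and higher numbers for weaker inhibition), compound 1 `O=C(N/N=C/c1ccccc1O)c1cc(-c2ccccc2)nn1Cc1ccccc1` gives 11000 nM, and compound 2 `CC(C)(C)c1ccc(Cn2nc(-c3ccccc3)cc2C(=O)N/N=C/c2ccccc2O)cc1` gives 6230 nM. Among the compounds with values here, compound 2 stands at one end of these two numbers, yet the single step of a 1.8-fold lower number from compound 1 to compound 2 (0.25 log units; within the scatter) lies within the scatter, so the two are not separated. Compound 3 `CC(C)(C)c1ccc(Cn2nc(-c3ccc(Cl)cc3)cc2C(=O)N/N=C/c2ccccc2O)cc1` differs from compound 2 by chloro in place of hydrogen on an aromatic carbon. Within the data shown here, no measured step bears on a chloro change; the one step seen, the tert-butyl step, stayed within the scatter. Compound 3 is therefore expected to remain near compound 2, with a 1.2-fold lower number from compound 2 to compound 3 (0.10 log units; within the scatter). The estimate for compound 3 is 5000 nM, between 2000 nM and 14000 nM.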

Compound 3, half-maximal inhibitory concentration: 3390 nM
Beside the measured number, compound 3's estimate is 1.5-fold (0.17 log units) above it; measured number inside the range.
By their numbers in this assay, from the lowest: compounds 3, 2 and 1 (each within the scatter of the next, the first and the last beyond it).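

Chloro in place of hydrogen, on the aromatic carbon para to a large group, gives a 1.8-fold lower number from compound 2 to compound 3 (0.26 log units; within the scatter) in this assay and so does not separate phenyl from 4-chlorophenyl. Within the data shown here, this is the only reading on this ring, as the earlier step concerned tert-butyl in place of hydrogen on the other aromatic ring, and both single changes stay within the scatter. Nothing measured here accounts for the result. Open, on these data alone, is whether an amine or a carboxylic acid at this same place would give a step beyond the scatter.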